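Series notes: carbonyl group in place of butyl on ring nitrogen

The source may hold more compounds than are shown below. What is called first, only, known or untested is meant among the compounds shown, and "the series" means these compounds.

Measured so far:
compound 1 `O=C1c2sc(C#Cc3ccccc3)nc2CN1C1CC1` — > 10000 nM
compound 2 `CCCCN1CCc2nc(C#Cc3ccccc3)sc2C1` — 110 nM
compound 3 `Fc1cccc(C#Cc2nc3c(s2)CN(C2CCOC2)CC3)c1` — > 10000 nM

Going by the values given here, in an assay on HEK293 cells for positive allosteric modulation of metabotropic glutamate receptor 5 (Homo sapiens), read by FLIPR, with a stated time of 1 h (a higher number here means that more compound is needed for the effect, a lower number that less compound is needed), compound 2 gives 110 nM, and this is the only number among the three values shown. Compound 1 returns only a limit, > 10000 nM. Compound 3 also returns a limit, > 10000 nM. Among the compounds with values here, both of these sit at the limit of > 10000 nM in this assay, at which 2 of the 3 values shown sit, so compound 2 stands alone as the one compound with a measured concentration, and no step between two measured compounds can be drawn from the set.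

Compound 4 `COC1CC(C(=O)N2CCc3nc(C#Cc4ccccc4)sc3C2)C1` differs from compound 2 in one place: (3-methoxycyclobutyl)carbonyl in place of butyl on an amine nitrogen in a ring. Within the data shown here, with no measured step to lean on, the expectation rests on compound 2 alone. The step from compound 2 to compound 4 is expected to go toward more compound needed, by a 9.1-fold higher number from compound 2 to compound 4 (0.96 log units; beyond the scatter), beyond the scatter. Compound 4 is estimated at 1000 nM in this assay, with a range from 150 nM to 8000 nM, and a real chance that only a limit is returned.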

Compound 4, half-maximal effective concentration: 640 nM
Compound 4: the middle estimate sits 1.6-fold (0.19 log units) above what was measured; measured number inside the range.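

In this assay, the amine nitrogen in a ring now has its first measured change: replacing butyl with (3-methoxycyclobutyl)carbonyl gives a 5.8-fold higher number from compound 2 to compound 4 (0.76 log units; beyond the scatter). This single step shows that the position is sensitive to the change, while a carbonyl-bearing substituent with a four-membered ring still leaves a measurable response in this series. Compound 4 returns a number and not a limit, so this step can be read, unlike any comparison with the compounds that return only a limit: the limit of > 10000 nM in this assay, at which 2 of the 4 values shown sit.

Going by these compounds alone, the single step does not separate the contributions of the carbonyl, the four-membered ring and the methoxy group. An acetyl group, or a 3-methoxycyclobutyl group without the carbonyl, on the same nitrogen would show how much of the step belongs to each part.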